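The source may report more compounds than this note shows. Statements on the series, on what has been measured and on what is new or still open speak of the compounds shown alone.

Working notes on the series, cytotoxicity read-out. Compound 1 `CN(c1ccc(NC(=O)c2cc(C(F)(F)F)cc(C(F)(F)F)c2)cc1OCc1ccccc1C(F)(F)F)S(C)(=O)=O` and compound 3 `CCCCCCOc1cc(NC(=O)c2cc(C(F)(F)F)cc(C(F)(F)F)c2)ccc1N(C)S(C)(=O)=O` share one core; compound 2 `CN(c1ccc(NC(=O)c2ccc(C(F)(F)F)cc2C(F)(F)F)cc1OCc1ccccc1C(F)(F)F)S(C)(=O)=O` is a close relative of compound 1 with the same amide and the same ether side chain. In an ADME assay on HEK293 cells (Homo sapiens) for cytotoxicity, read by MTT assay, with a stated time of 48 h (on this read-out lower numbers stand for stronger inhibition and higher numbers for weaker inhibition), compound 1 gives > 500000 nM, which is a limit of the assay and not a number. In this assay compound 2 likewise gives > 500000 nM, again a limit. Compound 1 thus stands at the limit of > 500000 nM in this assay, at which 2 of the 2 values shown sit, with no number to place it within the series. The change from compound 1 to compound 3 is pentyl in place of 2-(trifluoromethyl)phenyl on a saturated chain carbon bound to an oxygen on an aromatic ring. For the measured compounds named here, no step between measured compounds exists to set a scale for this change. The expectation is no step beyond the usual scatter, with a number no higher from compound 1 to compound 3 (the limit leaves the size open) as the estimated step. Compound 3 is expected to give 500000 nM, within 200000 nM to 1000000 nM, and most likely again only a limit.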

Compound 3, half-maximal inhibitory concentration: > 500000 nM
Compound 3: no number, only a limit (the forecaster's own chance of this, stated with the estimate: 80%); the middle value lies on the limit itself.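

No step can be read between compound 1 and compound 3, because both remain limits and not numbers: the limit of > 500000 nM in this assay, at which 3 of the 3 values shown sit.

The compounds shown leave open where compound 1, compound 2 and compound 3 truly lie, and whether hexyl in place of 2-(trifluoromethyl)benzyl alters the cytotoxicity read-out at all.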